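Cytotoxicity on HEp-2 cells: from compound 2 to compound 3

The source may report more compounds than this note shows. Statements on the series, on what has been measured and on what is new or still open speak of the compounds shown alone.

Measured compounds:
compound 1, `Cc1ccc2nc(N3CCCc4ccc(F)cc4C3)cc(NCCN(C)C)c2c1`, 89000 nM
compound 2, `Cc1ccc2nc(N3CCCc4ccc(F)cc4C3)cc(NCC(C)(C)N)c2c1`, 23000 nM

Both were tested in an ADME assay on HEp-2 cells (Homo sapiens) for cytotoxicity, read by CCK-8 assay, with a stated time of 5 days; a lower number here means that less compound is tolerated, a higher number that more compound is tolerated. Compound 2 shows the lowest of the two numbers; its nearest neighbour is compound 1, and the step from compound 1 to compound 2 is a 3.9-fold lower number from compound 1 to compound 2 (0.59 log units; beyond the scatter), where the change was 1-amino-1-methylethyl in place of (dimethylamino)methyl on a saturated chain carbon bound to a nitrogen on an aromatic ring.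

Compound 3, `Cc1ccc2nc(N3CCCc4ccc(F)cc4C3)cc(NCCN3CCCCC3)c2c1`, has not yet been measured. It differs from compound 2 in one place: (piperidin-1-yl)methyl in place of 1-amino-1-methylethyl on a saturated chain carbon bound to a nitrogen on an aromatic ring. Among the measured compounds shown here, this partly reverses the one measured step, since the (dimethylamino)methyl of compound 1 and the (piperidin-1-yl)methyl of compound 3 both carry no hydrogen-bond donor, while the 1-amino-1-methylethyl of compound 2 carries one. The step from compound 1 to compound 2 was a 3.9-fold lower number from compound 1 to compound 2 (0.59 log units; beyond the scatter), so a modest step back toward a higher number is expected for compound 3, roughly a 2.0-fold higher number from compound 2 to compound 3 (0.29 log units; within the scatter). The expected value for compound 3 in this assay is 45000 nM, within a range from 15000 nM to 130000 nM.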

Compound 3, half-maximal cytotoxic concentration: 22000 nM
Compound 3: the middle estimate sits 2.0-fold (0.31 log units) above what was measured, within the range that was stated.
By their numbers in this assay, from the lowest: compounds 3 and 2 (each within the scatter of the next); then compound 1.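

In this assay, putting (piperidin-1-yl)methyl in place of 1-amino-1-methylethyl on a saturated chain carbon bound to a nitrogen on an aromatic ring gives a 1.0-fold lower number from compound 2 to compound 3 (0.02 log units; within the scatter), so swapping these two groups, which differ in size, ring and hydrogen-bond donor, leaves no difference that can be read. The step from the dimethylamino group to piperidin-1-yl, on a saturated chain carbon, two bonds along the chain from a nitrogen on an aromatic ring, gives a 4.0-fold lower number from compound 1 to compound 3 (0.61 log units; beyond the scatter), which shows that two end groups without a hydrogen-bond donor can still differ beyond the scatter, so the presence or absence of that donor does not sort these compounds: compound 3 lacks it yet sides with compound 2, and only compound 1 stands apart. Nothing among the available measurements offers an explanation for these numbers.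

From the compounds shown here alone, it remains open whether a pyrrolidin-1-yl or morpholin-4-yl group at the end of the same chain would read like compound 3 or like compound 1. Going by these compounds, a longer chain carrying the piperidin-1-yl group is equally open.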